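A few compounds are considered here, and "the series" means these few. Any claim that something is new, unique, unknown or untested is made for them only; others in the source may bear on it.

Compound 1, `CC(O)(CSc1cccc(S(F)(F)(F)(F)F)c1)C(=O)Nc1ccc(C#N)cc1C(F)(F)F`, is the thioether member of this small set; in a functional assay on VCaP cells (Homo sapiens) for antiproliferative activity, read by propidium iodide staining, with a stated time of 96 h (a lower number here means a stronger inhibitor, a higher number a weaker inhibitor), compound 1 gives 30800 nM. Compound 2, `CC(O)(CSc1cccc(S(F)(F)(F)(F)F)c1)C(=O)Nc1ccc([N+](=O)[O-])cc1C(F)(F)F`, differs from it by nitro in place of cyano on an aromatic carbon; in this assay compound 2 gives 28800 nM, and the step of a 1.1-fold lower number from compound 1 to compound 2 (0.03 log units; within the scatter) is small. Compound 3, `CC(O)(COc1cccc(S(F)(F)(F)(F)F)c1)C(=O)Nc1ccc(C#N)cc1C(F)(F)F`, carries the same nitrile-bearing portion as compound 1 on a different core; the difference between the two cores is not broken down here. In this assay compound 3 gives 10300 nM, the lowest of the three numbers, and its gaps to compound 2 and compound 1 lie beyond the scatter. Compound 4, `CC(O)(COc1cccc(S(F)(F)(F)(F)F)c1)C(=O)Nc1ccc([N+](=O)[O-])cc1C(F)(F)F`, has not yet been measured in this assay. Among the compounds with values here, it differs from compound 3 by nitro in place of cyano on an aromatic carbon, the same change as the one made from compound 1 to compound 2, at the same place. Because a 1.1-fold lower number from compound 1 to compound 2 (0.03 log units; within the scatter) barely moved the number, the step from compound 3 to compound 4 is expected to be about a 1.1-fold lower number from compound 3 to compound 4 (0.04 log units; within the scatter). Compound 4 is therefore estimated to give about 9500 nM in this assay, with a range from 4500 nM to 20000 nM.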

Compound 4, half-maximal inhibitory concentration: 20300 nM
Compound 4: middle estimate off by 2.1-fold (0.33 log units), on the low side, outside the stated range (above it).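

In this assay, the second use of the change gives a 2.0-fold higher number from compound 3 to compound 4 (0.29 log units; within the scatter), a step that stays within the scatter, as the first one did. Set side by side, the two steps cannot be told apart: the same change on two cores in this assay, a 1.1-fold lower number (0.03 log units; within the scatter) from compound 1 to compound 2 and a 2.0-fold higher number (0.29 log units; within the scatter) from compound 3 to compound 4, 2.1-fold (0.32 log units) apart, within the scatter of two such steps. This shows that the change from cyano to nitro carried from one core to the other without a difference that these measurements can resolve, but it does not show that the two steps are the same size, and two pairs in a single cell assay say nothing about how the change would behave on any further core.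

The compounds shown leave open how other groups would fare in the place held by cyano and nitro, such as a chlorine atom, a carboxylic acid or an amine. They also leave open whether the change would carry over to a core with a longer chain or an amine in the link that differs between the two cores.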